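The source may hold more compounds than are shown below. What is called first, only, known or untested is meant among the compounds shown, and "the series" means these compounds.

Working notes on the series. Compound 1 `Cc1nc(S(C)(=O)=O)ccc1Oc1ncnc(OC2CCN(C(=O)O[C@H](C)C(F)(F)F)CC2)c1F` gives 9.2 nM in a functional assay on isolated protein for inhibition of Glucose-dependent insulinotropic receptor (Homo sapiens), read by HTRF and cAMP accumulation; a higher number here means that more compound is needed for the effect, a lower number that less compound is needed; compound 2 `Cc1nc(S(C)(=O)=O)ccc1Oc1ncnc(OC2CCN(C(=O)O[C@@H](C)C(F)(F)F)CC2)c1F` gives 9.86 nM, and the step of a 1.1-fold higher number from compound 1 to compound 2 (0.03 log units; within the scatter) is explained by the fact that compounds 1 and 2 differ only in the configuration as drawn. Compound 3 `Cc1nc(S(C)(=O)=O)ccc1Oc1ncnc(OC2CCN(C(=O)C(C)(C)F)CC2)c1F` gives 76.3 nM, the highest of the three numbers, nearest to the number of compound 2; the steps into it were a 7.7-fold higher number from compound 2 to compound 3 (0.89 log units; beyond the scatter) and an 8.3-fold higher number from compound 1 to compound 3 (0.92 log units; beyond the scatter). Compound 4 `Cc1nc(S(C)(=O)=O)ccc1Oc1ncnc(OC2CCN(C(=O)C3(F)CCC3)CC2)c1F` is not yet measured. From compound 3 to compound 4, (a group of 5 heavy atoms (4 carbon, 1 fluorine; one four-membered non-aromatic ring of carbon only) in place of a group of 4 heavy atoms (3 carbon, 1 fluorine; no ring), on a carbonyl carbon). Within the data shown here, both measured steps into compound 3 swapped 1-(trifluoromethyl)ethoxy for a fluorinated carbon group and raised the number; the step to compound 4 keeps such a group and only closes it into a four-membered ring, for which no measured step exists. A step within or near the scatter is expected, a 1.3-fold lower number from compound 3 to compound 4 (0.10 log units; within the scatter). Compound 4 is therefore estimated at 60 nM, expected range 20 nM to 180 nM.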

Compound 4, half-maximal effective concentration: 24.7 nM
The estimate for compound 4 lay 2.4-fold (0.39 log units) above the measured number; measured number inside the range.
By their numbers in this assay, from the lowest: compounds 1 and 2 (each within the scatter of the next); then compound 4; then compound 3.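

On this carbonyl carbon, ring size and shape of the fluorinated carbon group matter in this assay: closing 1-fluoro-1-methylethyl into the four-membered ring gives a 3.1-fold lower number from compound 3 to compound 4 (0.49 log units; beyond the scatter) and thus recovers part of what was lost. The ring does not fully match 1-(trifluoromethyl)ethoxy, with a 2.5-fold higher number from compound 2 to compound 4 (0.40 log units; beyond the scatter) and a 2.7-fold higher number from compound 1 to compound 4 (0.43 log units; beyond the scatter) still remaining. Nothing available bears on the reason for these steps.

On these data alone, whether the ring needs its fluorine remains open, as does the outcome with a cyclopropyl or cyclopentyl ring, or with an amine, on this carbonyl carbon.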